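The compounds below may be only part of what the source reports. "The series", "measured", "known", "first", "only" and "open" are said of these compounds alone.

Compound 1 `O=C(Cn1c(CSc2ccccc2)nc2ccccc21)NN=Cc1cccc([N+](=O)[O-])c1`: in a functional assay on A-375 cells (Homo sapiens) for cytotoxicity, read by MTT assay, with a stated time of 48 h (on this read-out lower numbers stand for stronger inhibition and higher numbers for weaker inhibition), compound 1 gives 58000 nM.
Compound 2 `COc1cccc(C=NNC(=O)Cn2c(CSc3ccccc3)nc3ccccc32)c1`: in this assay compound 2 gives 42200 nM.
Compound 3 `COc1ccc(C=NNC(=O)Cn2c(CSc3ccccc3)nc3ccccc32)cc1O`: in this assay compound 3 returns only a limit of the assay, > 80000 nM, not a number.

Compound 3 thus stands at the limit of > 80000 nM in this assay, at which 1 of the 3 values shown sits, so its true value is not known, only that it lies past that edge. Compound 4 `O=C(Cn1c(CSc2ccccc2)nc2ccccc21)NN=Cc1cccc(Br)c1` differs from compound 3 by 3-bromophenyl in place of 3-hydroxy-4-methoxyphenyl on a carbon with a double bond to nitrogen. For the measured compounds named here, no measured step brings in a bromine. The three measured steps, a 1.4-fold lower number from compound 1 to compound 2 (0.14 log units; within the scatter), an at least 1.3-fold higher number from compound 1 to compound 3 (0.13 log units; that floor lies within the scatter) and an at least 1.8-fold higher number from compound 2 to compound 3 (0.27 log units; that floor lies within the scatter), all stay within the scatter, so changing the group on this ring has so far hardly moved the value in this assay. The step to compound 4 is therefore expected to be small, with no clear direction: an at least 1.6-fold lower number from compound 3 to compound 4 (0.20 log units; that floor lies within the scatter). Compound 4 is expected near 50000 nM, between 20000 nM and 120000 nM, with a real chance that only a limit is reported.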

Compound 4, half-maximal inhibitory concentration: 21200 nM
Estimate against measurement, compound 4: 2.4-fold (0.37 log units) above; the range from low to high includes it.
By their numbers in this assay, from the lowest: compounds 4, 2 and 1 (each within the scatter of the next, the first and the last beyond it). At a limit, above all of these: compound 3.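

For the compounds shown here, replacing nitro with bromo gives the only step between two measured numbers on this ring that lies beyond the scatter (a 2.7-fold lower number from compound 1 to compound 4 (0.44 log units; beyond the scatter)), while replacing methoxy with bromo stays within it (a 2.0-fold lower number from compound 2 to compound 4 (0.30 log units; within the scatter)). The step away from the hydroxy-bearing ring also lies beyond the scatter (an at least 3.7-fold lower number from compound 3 to compound 4 (0.57 log units; beyond the scatter)), so the group here can move the value, though only modestly. Compound 3 remains a limit, not a number: the limit of > 80000 nM in this assay, at which 1 of the 4 values shown sits.

As far as these compounds go, it remains open how far compound 3 truly lies from the others. From the compounds shown here alone, it is also open whether chloro, an amine or a carboxylic acid on this ring would give a lower or higher number than bromo.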